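Chloro on the Core: Expected Cytotoxicity of Compound 4

A few compounds are considered here, and "the series" means these few. Any claim that something is new, unique, unknown or untested is made for them only; others in the source may bear on it.

Compound 1 `Cc1ccc2[nH]c(=O)c(CN(Cc3cccc(F)c3)Cc3ccc4ccccc4c3)cc2c1` gives > 5000 nM in a toxicity assay on MDCK cells (Canis lupus familiaris) for cytotoxicity, read by crystal violet staining, with a stated time of 48 h (on this read-out lower numbers stand for higher toxicity in this test and higher numbers for lower toxicity in this test), a limit of the assay.
Compound 2 `COc1ccc([C@H](C)N(Cc2ccc(C(C)(C)C)cc2)Cc2cc3ccccc3[nH]c2=O)cc1` gives 1800 nM.
Compound 3 `COc1ccc([C@H](C)N(Cc2ccc(OC(F)(F)F)cc2)Cc2cc3ccccc3[nH]c2=O)cc1` gives > 10000 nM, which is a limit of the assay, so no exact number is known for it.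

Compound 4 `COc1ccc([C@H](C)N(Cc2ccc(OC(F)(F)F)cc2)Cc2cc3cc(Cl)ccc3[nH]c2=O)cc1` differs from compound 3 in one place: chloro in place of hydrogen on an aromatic carbon. Among the measured compounds shown here, the only measured step, an at least 5.5-fold higher number from compound 2 to compound 3 (0.74 log units; beyond the scatter), changed a group on a side arm, not the shared core, so it bears only loosely on this change. For the measured compounds named here, with no measured step touching the core, the expected outcome is no step beyond the scatter, a number no higher from compound 3 to compound 4 (the limit leaves the size open). Compound 4 is therefore estimated at 10000 nM, within 3000 nM to 30000 nM, most likely again reported as a limit.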

Compound 4, half-maximal cytotoxic concentration: > 10000 nM
Compound 4 gave a limit, no number (the forecaster's own chance of this, stated with the estimate: 60%); the middle value lies on the limit itself.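

Compound 3 and compound 4 both give only a limit of the assay, not a number, so the step between them cannot be read. From the compounds shown here alone, whether chloro in place of hydrogen on the shared core changes the half-maximal cytotoxic concentration at all remains open.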